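A few compounds are considered here, and "the series" means these few. Any claim that something is new, unique, unknown or untested is made for them only; others in the source may bear on it.

Compound 1 `CO[C@]1(C(=O)N2CC[C@](c3ccc(C(F)(C(F)(F)F)C(F)(F)F)cc3)(S(=O)(=O)c3ccc(F)cc3)C2)CC[C@H](C(=O)O)CC1`: 82%
Compound 2 `O=C(O)C12CCC(C(=O)N3CC[C@](c4ccc(C(F)(C(F)(F)F)C(F)(F)F)cc4)(S(=O)(=O)c4ccc(F)cc4)C3)(CC1)OC2`: 90%
Compound 3 `O=C(N1CC[C@](c2ccc(C(F)(C(F)(F)F)C(F)(F)F)cc2)(S(=O)(=O)c2ccc(F)cc2)C1)C12CCC(C(=O)O)(CC1)OC2`: "not determined" (no result reported)

These three compounds share one core and differ in the group on a carbonyl carbon. In an ADME assay on microsomes from liver (Homo sapiens) for metabolic stability, with a stated time of 10 min (on this read-out higher numbers stand for a more stable compound and lower numbers for a less stable compound), compound 1 gives 82% and compound 2 gives 90%. Compound 3 has no reported result, so it offers no number to start from, and only its structure can be compared.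

The next compound is compound 4 `CCC1(C(=O)N2CC[C@](c3ccc(C(F)(C(F)(F)F)C(F)(F)F)cc3)(S(=O)(=O)c3ccc(F)cc3)C2)CCS(=O)(=O)CC1`. Going from compound 3 to compound 4, the change is a group of 10 heavy atoms (7 carbon, 2 oxygen, 1 sulfur; one six-membered non-aromatic ring with 1 hetero atom) in place of a group of 11 heavy atoms (8 carbon, 3 oxygen; one six-membered non-aromatic ring of carbon only, one six-membered non-aromatic ring with 1 hetero atom), on a carbonyl carbon. The entering group is 4-ethyl-1,1-dioxothian-4-yl, and it sits on the same carbonyl carbon, whose other neighbour of note is an amide-type nitrogen in a ring.

Within the data shown here, only one measured step bears on this, a number 8 percentage points higher from compound 1 to compound 2 (within the scatter). It also exchanges one group for another at this place, and it stays within the scatter. However, neither measured compound carries the entering group, so that step is only weak guidance. With no number for compound 3, no size or direction can be given for the step itself. Compound 4 is expected to fall in the region of the two measured values, with more room on the low side. The expected value for compound 4 is 78%, with an estimated range of 52% to 93%.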

Compound 4, percent of the compound remaining: 3%
Beside the measured number, compound 4's estimate is 75 percentage points above it; measured number below the stated range.
By their numbers in this assay, from the lowest: compound 4; then compounds 1 and 2 (each within the scatter of the next).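

Among these compounds, until now, the only step read at the group on the carbonyl carbon lay within the scatter in this assay. The entry of 4-ethyl-1,1-dioxothian-4-yl shows that this place can also carry a large change, with a number 87 percentage points lower from compound 2 to compound 4 (beyond the scatter), and a number 79 percentage points lower from compound 1 to compound 4 (beyond the scatter). No measurement shown explains so steep a fall.

The swap changes several things at once: the carboxy group of 4-carboxy-1-methoxycyclohexyl leaves, the count goes from 1 hydrogen-bond donor to 0 hydrogen-bond donors, and sulfur and an ethyl group enter, so the compounds shown leave open which of these parts goes with the low number. Also open, going by these compounds, is how the number would respond if the ethyl group on the 1,1-dioxothian ring gave way to an amine or a hydroxyl group, or if a carboxylic acid stood there, which would separate the effect of the ring from that of its substituent.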